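The compounds below may be only part of what the source reports. "The series", "measured", "known", "first", "only" and "open" are said of these compounds alone.

Measured in a functional assay on BeWo cells (Homo sapiens) for inhibition, read by MTT assay; on this read-out lower numbers stand for stronger inhibition and higher numbers for weaker inhibition:

- Compound 1 `CC1(C)C2CCC1(C)C(OC(=O)/C=C/c1cc(O)c(O)c(Br)c1)C2`: 20000 nM
- Compound 2 `CC1(C)C2CCC1(C)C(OC(=O)/C=C/c1ccc(O)c(O)c1)C2`: 35900 nM

Only these two compounds have been measured so far, so compound 2, at 35900 nM, can be placed only against compound 1. The two lie within the usual scatter of each other, and neither can be ranked above the other.

Compound 3 `CC1(C)C2CCC1(C)C(OC(=O)/C=C/c1cc(O)c(O)c(Cl)c1)C2` is derived from compound 2 by one change, chloro in place of hydrogen on an aromatic carbon, ortho to a hydroxy group and meta to a second hydroxy group: chloro in place of hydrogen on an aromatic carbon. Within the data shown here, one measured step bears on this change: a 1.8-fold higher number from compound 1 to compound 2 (0.25 log units; within the scatter). There, hydrogen takes the place of bromo at the same carbon. Read in reverse, this step concerns adding a different halogen, and it stays within the scatter. The data therefore give no reason to expect a real shift in this assay, and any movement towards the value of compound 1 would be slight. The expected step is a 1.6-fold lower number from compound 2 to compound 3 (0.19 log units; within the scatter), which would remain within the scatter. In this assay the estimate for compound 3 is 23000 nM, with an expected range from 11000 nM to 46000 nM.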

Compound 3, half-maximal inhibitory concentration: 51900 nM
Estimate against measurement, compound 3: 2.3-fold (0.35 log units) below; measured number outside the range, above it.
By their numbers in this assay, from the lowest: compounds 1, 2 and 3 (each within the scatter of the next, the first and the last beyond it).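

In this assay, chloro on the aromatic carbon ortho to a hydroxy group and meta to a hydroxy group gives a 1.4-fold higher number from compound 2 to compound 3 (0.16 log units; within the scatter) and so cannot be told apart from hydrogen at this position. Among these compounds, the comparison between the two halogens at the same carbon is sharper: chloro in place of bromo gives a 2.6-fold higher number from compound 1 to compound 3 (0.41 log units; beyond the scatter) and is the first step here to pass beyond the scatter, though only modestly, so compound 1 and compound 3 can be separated even though neither can be separated from compound 2. No supporting evidence is available to account for this difference between bromo and chloro.

Going by these compounds, the three compounds vary only this one carbon and only among hydrogen, chloro and bromo, so it remains open whether fluoro, methyl or methoxy there would stand apart from hydrogen or follow either halogen. On these data alone, it is also open how far the separation between compound 1 and compound 3 would hold with a methoxy group in place of either hydroxy group.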